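The source may hold more compounds than are shown below. What is called first, only, known or untested is meant among the compounds shown, and "the series" means these compounds.

Compound 1 `CC(C)CCNC(=O)c1ccc(C#Cc2ccccc2)nc1` and compound 2 `CC1CCC(NC(=O)c2ccc(C#Cc3ccccc3)nc2)CC1` share one core and differ only in the group on the amide nitrogen. Among the measured compounds shown here, in a functional assay on BHK cells for positive allosteric modulation of metabotropic glutamate receptor 5 (Homo sapiens), read by FLIPR and calcium flux (a lower number here means that less compound is needed, a higher number that more compound is needed for the effect), compound 1 gives 510 nM, the lowest of the two numbers so far; compound 2 gives 1200 nM. For the measured compounds named here, the only measured step, a 2.4-fold higher number from compound 1 to compound 2 (0.37 log units; beyond the scatter), exchanges the open chain on the amide nitrogen for a ring.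

Compound 3 `O=C(NCc1ccco1)c1ccc(C#Cc2ccccc2)nc1` is not yet measured. Going by the values given here, it differs from compound 1 by furan-2-yl in place of isobutyl on a saturated chain carbon bound to an amide-type nitrogen, again an open-chain piece traded for a ring at the amide side, so the step to compound 2 is the only guide. That step was modest and upward, and a similar size is expected here, though a ring of a different kind offers no firmer basis. For compound 3 a value of 750 nM in this assay is estimated, with a range of 250 nM to 2200 nM, meaning an expected step of a 1.5-fold higher number from compound 1 to compound 3 (0.17 log units; within the scatter).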

Compound 3, half-maximal effective concentration: 180 nM
Beside the measured number, compound 3's estimate is 4.2-fold (0.62 log units) above it, and the stated range ends above it.
By their numbers in this assay, from the lowest: compound 3; then compound 1; then compound 2.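

In this assay a ring group on the amide side is not in itself a penalty: furan-2-yl in place of isobutyl on the saturated chain carbon gives a 2.8-fold lower number from compound 1 to compound 3 (0.45 log units; beyond the scatter), the opposite direction to the earlier change to 4-methylcyclohexyl, a 2.4-fold higher number from compound 1 to compound 2 (0.37 log units; beyond the scatter). The largest step so far, a 6.7-fold lower number from compound 2 to compound 3 (0.82 log units; beyond the scatter), separates two ring-bearing groups, so among these three compounds the kind of ring group matters more than the presence of a ring. The change brings in a five-membered aromatic ring with an oxygen atom, but no evidence here shows which feature accounts for the lower number.

Open, going by these compounds, is whether the furan oxygen is needed, which a benzyl or (thiophen-2-yl)methyl group on the amide nitrogen would address. Also open, on these data alone, is how a longer chain carrying the furan-2-yl would compare.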